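Adding a methyl to compound 3

A few compounds are considered here, and "the series" means these few. Any claim that something is new, unique, unknown or untested is made for them only; others in the source may bear on it.

Measured in a functional assay on A549 cells (Homo sapiens) for inhibition, read by sulforhodamine B assay, with a stated time of 48 h; on this read-out higher numbers stand for weaker inhibition of growth and lower numbers for stronger inhibition of growth:
compound 1 `Cc1ccn2c(CN3CCCCC3)c(-c3ccccc3)nc2n1`: 4040 nM
compound 2 `Cc1ccn2c(CN3CCCC3)c(-c3ccc(O)cc3)nc2n1`: 2480 nM
compound 3 `c1ccc(-c2nc3ncccn3c2CN2CCCC2)cc1`: 50 nM

Compound 3 has the lowest of the three numbers in this assay, which makes it the strongest growth inhibitor so far. Compounds 1 and 2 both read higher, and both gaps lie beyond the usual scatter.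

The next compound is compound 4 `Cc1ccn2c(CN3CCCC3)c(-c3ccccc3)nc2n1`, which differs from compound 3 in one place: methyl in place of hydrogen on an aromatic carbon of the six-membered aromatic ring with 2 nitrogen (methyl in place of hydrogen on an aromatic carbon).

Among the compounds with values here, no measured pair isolates this change, so the evidence is indirect. Compound 1 carries the same methyl and reads 4040 nM, and compound 2 also carries it and reads 2480 nM. From the compounds shown here alone, each of them also differs from compound 3 elsewhere, so neither gives a clean comparison, and the size of the methyl step remains open. Even so, both values point towards weaker inhibition of growth. The expected change is a 30-fold higher number from compound 3 to compound 4 (1.48 log units; beyond the scatter), an upward move beyond the scatter. For compound 4 the estimate is 1500 nM, with an expected range of 300 nM to 5000 nM.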

Compound 4, concentration for 50% growth inhibition: 4150 nM
Beside the measured number, compound 4's estimate is 2.8-fold (0.44 log units) below it; measured number inside the range.
By their numbers in this assay, from the lowest: compound 3; then compounds 2, 1 and 4 (each within the scatter of the next).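

Within the data shown here, the methyl on an aromatic carbon of the six-membered aromatic ring with 2 nitrogen now has a clean pair: in this assay the change gives an 83-fold higher number from compound 3 to compound 4 (1.92 log units; beyond the scatter) and is the first reading of this change alone. Among the compounds that carry the methyl, the other two changes can also be read singly: hydrogen in place of hydroxy gives a 1.7-fold higher number from compound 2 to compound 4 (0.22 log units; within the scatter) and pyrrolidin-1-yl in place of piperidin-1-yl gives a 1.0-fold higher number from compound 1 to compound 4 (0.01 log units; within the scatter) as the second of these steps. With the methyl present, neither of those two changes moves the number beyond the scatter, while the methyl step itself is large.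

Still open, from the compounds shown here alone, is whether an ethyl, a methoxy or a chlorine on the same aromatic carbon reads like hydrogen or like methyl, and whether hydroxy or piperidin-1-yl would also leave the number unmoved on the core of compound 3, which lacks the methyl. Nothing in hand accounts for the size of the methyl step.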